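Replacing the Ester Group of Compound 2

A few compounds are considered here, and "the series" means these few. Any claim that something is new, unique, unknown or untested is made for them only; others in the source may bear on it.

In a functional assay on MDA-MB-231 cells (Homo sapiens) for antiproliferative activity, read by MTT assay, with a stated time of 72 h (a higher number here means a weaker inhibitor, a lower number a stronger inhibitor), compound 1 (`CC1=CC[C@H]2[C@H](CC[C@]2(C)O)C(C)(C)[C@@H]1CC[C@H]1[C@]2(C)CC[C@H](OC(=O)c3ccncc3)C(C)(C)O[C@H]2CC[C@@]1(C)O`) gives 18000 nM, and compound 2 (`CC1=CC[C@H]2[C@H](CC[C@]2(C)O)C(C)(C)[C@@H]1CC[C@H]1[C@]2(C)CC[C@H](OC(=O)c3ccccc3[N+](=O)[O-])C(C)(C)O[C@H]2CC[C@@]1(C)O`) gives 38700 nM, the higher of the two numbers. Compound 3 (`CC1=CC[C@H]2[C@H](CC[C@]2(C)O)C(C)(C)[C@@H]1CC[C@H]1[C@]2(C)CC[C@H](OC(=O)c3ccc(C(F)(F)F)c(F)c3)C(C)(C)O[C@H]2CC[C@@]1(C)O`) has 3-fluoro-4-(trifluoromethyl)phenyl in place of 2-nitrophenyl on a carbonyl carbon. Among the measured compounds shown here, the only measured change at this carbonyl carbon is modest, a 2.2-fold higher number from compound 1 to compound 2 (0.33 log units; beyond the scatter), and it does not involve the entering group. A similarly modest move toward a lower number is therefore expected in this assay. The estimated change is a 1.5-fold lower number from compound 2 to compound 3 (0.19 log units; within the scatter). Compound 3 is expected at 25000 nM, within a range of 10000 nM to 55000 nM.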

Compound 3, half-maximal inhibitory concentration: 22200 nM
Estimate against measurement, compound 3: 1.1-fold (0.05 log units) above, within the range that was stated.
By their numbers in this assay, from the lowest: compounds 1, 3 and 2 (each within the scatter of the next, the first and the last beyond it).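

In this assay the 3-fluoro-4-(trifluoromethyl)phenyl group, the first fluorine-bearing group shown on this carbonyl carbon, gives a 1.7-fold lower number from compound 2 to compound 3 (0.24 log units; within the scatter) and a 1.2-fold higher number from compound 1 to compound 3 (0.09 log units; within the scatter) so compound 3 cannot be told apart from either neighbour. This position therefore holds three different aromatic rings within a narrow band of numbers, although compound 1 and compound 2 remain beyond the scatter of each other. No evidence bears on why these numbers fall as they do. From the compounds shown here alone, whether an aminophenyl ring or a saturated chain such as hexanoyl would stay in this band remains open.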